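Removing One Methoxy Group From Compound 1

The source may hold more compounds than are shown below. What is called first, only, known or untested is meant among the compounds shown, and "the series" means these compounds.

Among the compounds with values here, compound 1 `COc1ccc(/C=C2/SC(NN3Cc4ccccc4N=C3c3ccccc3)=NC2=O)cc1OC` is one of three compounds measured in a functional assay on A549 cells (Homo sapiens) for cytotoxicity, read by MTT assay, with a stated time of 4 h (on this read-out lower numbers stand for stronger inhibition and higher numbers for weaker inhibition), where compound 1 gives 44700 nM. Compound 2 `O=C(CNc1ccc(Br)cc1)Nn1c(-c2ccccc2)nc2ccccc2c1=O` gives 25000 nM in this assay, and compound 3 `O=C(CNc1ccccc1)Nn1c(-c2ccccc2)nc2ccccc2c1=O` gives 13300 nM. Compound 1 sits at the high end of these numbers: its gap to compound 3 lies beyond the scatter, while its gap to compound 2 stays within it. Within the data shown here, the only single-point step among the measured compounds is a 1.9-fold lower number from compound 2 to compound 3 (0.27 log units; within the scatter), a change that stays within the scatter.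

Compound 4 `COc1ccc(/C=C2/SC(NN3Cc4ccccc4N=C3c3ccccc3)=NC2=O)cc1` differs from compound 1 by hydrogen in place of methoxy on an aromatic carbon. Among the measured compounds shown here, no measured pair shares this change; the step from compound 2 to compound 3 is the sole comparison available, it concerns a different group on a different core, and it was small. The data thus give no ground to expect a step beyond the scatter in this assay from compound 1 to compound 4, in either direction. Compound 4 is therefore expected to give about 45000 nM in this assay, with a range from 20000 nM to 100000 nM. The step this estimate means is a 1.0-fold higher number from compound 1 to compound 4 (0.00 log units; within the scatter), which is an expectation of essentially no change.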

Compound 4, half-maximal inhibitory concentration: 5310 nM
The estimate for compound 4 lay 8.5-fold (0.93 log units) above the measured number; the measured number lies below the stated range.
By their numbers in this assay, from the lowest: compound 4; then compounds 3, 2 and 1 (each within the scatter of the next, the first and the last beyond it).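

In this assay, the change from 3,4-dimethoxyphenyl to 4-methoxyphenyl gives an 8.4-fold lower number from compound 1 to compound 4 (0.93 log units; beyond the scatter), so this single replacement of methoxy by hydrogen moves the read-out beyond the scatter. Within the data shown here, the earlier compounds offered only one single-point step, a replacement of bromo by hydrogen on a different core that stayed within the scatter, and so gave no sign that a one-group change could matter this much here; this pair shows that the position on the core of compound 1, ortho to a methoxy group and meta to a large group, is one where the read-out responds to the group it carries. No measurement shown here bears on why the number falls with this change.

Whether hydrogen is specifically favoured at this position stays open, as the compounds shown do not reveal how a hydroxyl group, a fluorine atom, an amine or a longer chain such as ethoxy would fare there. Also open, on these data alone, are the effect of replacing the remaining methoxy group and whether the same change would give a step of similar size on another core.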